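The compounds below may be only part of what the source reports. "The series", "measured", "known", "first", "only" and "open" are said of these compounds alone.

Compound 1 `COc1cc(-c2ccnc3cc(-c4ccc(F)cc4)nn23)cc(OC)c1OC` stands at the weak end of the three measured compounds in a functional assay on B16-F0 cells (Mus musculus) for inhibition, read by CCK-8 assay, with a stated time of 48 h (on this read-out higher numbers stand for weaker inhibition and lower numbers for stronger inhibition), where compound 1 gives 4540 nM. Compound 2 `COc1cc(-c2ccnc3cc(-c4ccc(N(C)C)cc4)nn23)cc(OC)c1OC` gives 702 nM, and compound 3 `COc1ccc(-c2cc3nccc(-c4cc(OC)c(OC)c(OC)c4)n3n2)cc1` gives 1410 nM. Both measured steps leave compound 1 by changing the group on the same aromatic carbon: a 6.5-fold lower number from compound 1 to compound 2 (0.81 log units; beyond the scatter), and a 3.2-fold lower number from compound 1 to compound 3 (0.51 log units; beyond the scatter). Compound 4 `COc1cc(-c2ccnc3cc(-c4ccc5cnn(C)c5c4)nn23)cc(OC)c1OC` differs from compound 1 at that same place: 1-methyl-1H-indazol-6-yl in place of 4-fluorophenyl on an aromatic carbon. The measured steps bear on this only loosely, since each swaps a single substituent while here the whole 4-fluorophenyl is exchanged for a two-ring group; still, both replacements of fluoro gave a modest lowering. A modest lowering is therefore expected, a 3.0-fold lower number from compound 1 to compound 4 (0.48 log units; beyond the scatter). Compound 4 is estimated at 1500 nM, within 500 nM to 4500 nM.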

Compound 4, half-maximal inhibitory concentration: 1000 nM
Compound 4: middle estimate off by 1.5-fold (0.18 log units), on the high side, and the stated range covers the measured number.
By their numbers in this assay, from the lowest: compounds 2, 4 and 3 (each within the scatter of the next); then compound 1.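

In this assay, the change at this position need not be a single substituent on the phenyl ring: the two-ring 1-methyl-1H-indazol-6-yl also gives a 4.5-fold lower number from compound 1 to compound 4 (0.66 log units; beyond the scatter) against 4-fluorophenyl. Its number cannot be separated from those of the two other replacements, with a 1.4-fold lower number from compound 3 to compound 4 (0.15 log units; within the scatter) and a 1.4-fold higher number from compound 2 to compound 4 (0.15 log units; within the scatter) both within the scatter. Nothing here explains why these three groups differ from 4-fluorophenyl.

Open, on these data alone, is how this carbon tolerates a non-aromatic group, such as a carboxylic acid or a simple amine. Also open, as far as these compounds go, is whether 1H-indazol-6-yl, without its methyl, behaves the same.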